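Methyl for Methoxy on the Bromo Core

The source may report more compounds than this note shows. Statements on the series, on what has been measured and on what is new or still open speak of the compounds shown alone.

Compound 1 `COc1ccc(Cn2c(Cl)nc3cc(Cl)c(Cl)cc32)cc1` and compound 2 `Cc1ccc(Cn2c(Cl)nc3cc(Cl)c(Cl)cc32)cc1` share one core; compound 2 differs from compound 1 by methyl in place of methoxy on an aromatic carbon. In a functional assay on CEM-SS cells (Homo sapiens) for cytotoxicity (a lower number here means a stronger inhibitor, a higher number a weaker inhibitor), compound 1 gives only a limit, > 100000 nM. Compound 2 likewise gives only a limit, > 100000 nM. The step that the two limits leave unreadable from compound 1 to compound 2 thus stays hidden, due to the limit of > 100000 nM in this assay, at which 2 of the 3 values shown sit. Compound 3 `COc1ccc(Cn2c(Br)nc3cc(Cl)c(Cl)cc32)cc1` carries another core, which differs from that of compound 1 by bromo in place of chloro on an aromatic carbon; in this assay compound 3 gives 60000 nM, so the step of an at least 1.6-fold lower number from compound 1 to compound 3 (0.22 log units; that floor lies within the scatter) is read only as a floor. Compound 4 `Cc1ccc(Cn2c(Br)nc3cc(Cl)c(Cl)cc32)cc1`, not yet measured, differs from compound 3 by methyl in place of methoxy on an aromatic carbon, the same change as from compound 1 to compound 2. That earlier change left no readable step, and the expected step of a 1.3-fold higher number from compound 3 to compound 4 (0.12 log units; within the scatter) rests on that alone. Compound 4 is estimated at 80000 nM, between 30000 nM and 200000 nM, with a real chance that only a limit is reported.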

Compound 4, half-maximal inhibitory concentration: > 100000 nM
Compound 4: only a limit was reported (the forecaster's own chance of this, stated with the estimate: 40%); middle value at least 1.2-fold (0.09 log units) from the limit.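

In this assay compound 4 gives only a limit, > 100000 nM. On the core that carries bromo, methyl in place of methoxy therefore gives an at least 1.6-fold higher number from compound 3 to compound 4 (0.22 log units; that floor lies within the scatter), which is a floor and not a measured size. On these data alone, the same change on the chloro core, and the step from chloro to bromo between the two methyl compounds, cannot be read, so whether the change behaves alike on both cores remains unknown, due to one shared limit: the limit of > 100000 nM in this assay, at which 3 of the 4 values shown sit.

Within the data shown here, only compound 3 has a true number here, so no step between two true numbers exists. Also open, as far as these compounds go, is how an amine or a carboxylic acid in place of methoxy would read in this assay.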